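Aryl exchange at the carbonyl carbon in the series

The source may report more compounds than this note shows. Statements on the series, on what has been measured and on what is new or still open speak of the compounds shown alone.

Three compounds with a shared core have numbers in a functional assay on MCF7 cells (Homo sapiens) for inhibition, read by MTT assay; on this read-out lower numbers stand for stronger inhibition and higher numbers for weaker inhibition. Compound 1 `CCc1ccc(C(=O)Nc2ccc(Nc3ncnc4cc(OC)c(OC)cc34)cc2)cc1` gives 65000 nM, compound 2 `COc1cc2ncnc(Nc3ccc(NC(=O)c4ccc(Br)cc4)cc3)c2cc1OC` gives 43000 nM and compound 3 `COc1cc2ncnc(Nc3ccc(NC(=O)c4ccccc4I)cc3)c2cc1OC` gives 37000 nM. Compound 3 stands level with the other two, with a 1.2-fold lower number from compound 2 to compound 3 (0.07 log units; within the scatter) and a 1.8-fold lower number from compound 1 to compound 3 (0.24 log units; within the scatter). Both steps lie within the scatter, so the three values carry no order.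

Compound 4 `COc1cc2ncnc(Nc3ccc(NC(=O)c4cccc(C(F)(F)F)c4)cc3)c2cc1OC` has not yet been measured. It carries 3-(trifluoromethyl)phenyl in place of 2-iodophenyl on a carbonyl carbon.

The closest evidence comes from the two exchanges of the whole group on that carbon, the steps already given for compound 3. The remaining exchange, a 1.5-fold lower number from compound 1 to compound 2 (0.18 log units; within the scatter), also concerns that group. Among the compounds with values here, none of the three steps leaves the scatter, so the series so far shows little response to changes in this group. Within the data shown here, no measured compound carries 3-(trifluoromethyl)phenyl, however, which leaves the expectation resting on different groups. No step beyond the scatter is therefore expected in this assay, and no direction can be called.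

The estimated change is a 1.2-fold higher number from compound 3 to compound 4 (0.09 log units; within the scatter). For compound 4 the expected value is 45000 nM, with an estimated range from 22000 nM to 90000 nM.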

Compound 4, half-maximal inhibitory concentration: > 100000 nM
Compound 4: only a limit was reported; the forecaster's own chance of this, stated with the estimate: 10%; at least 2.2-fold (0.34 log units) between middle value and limit.
By their numbers in this assay, from the lowest: compounds 3, 2 and 1 (each within the scatter of the next). At a limit, above all of these: compound 4.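

In this assay compound 4 gives > 100000 nM, which is a limit of the assay and not a number. Within the data shown here, the position is less flat than the earlier steps suggested: 3-(trifluoromethyl)phenyl on the carbonyl carbon gives an at least 2.7-fold higher number from compound 3 to compound 4 (0.43 log units; beyond the scatter) and an at least 2.3-fold higher number from compound 2 to compound 4 (0.36 log units; beyond the scatter), the first steps to leave the scatter, so an aryl exchange here can raise the number, whereas an at least 1.5-fold higher number from compound 1 to compound 4 (0.18 log units; that floor lies within the scatter) does not yet separate those two compounds. These steps are floors only, and just one compound shown reaches the top of the read-out: the limit of > 100000 nM in this assay, at which 1 of the 4 values shown sits.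

The compounds shown do not separate the effect of the trifluoromethyl group from that of its place on the phenyl ring, and the true size of each step past the limit stays unknown. As far as these compounds go, how a phenyl ring bearing an amine or a carboxylic acid would read on this carbonyl carbon also stays open.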